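The source may report more compounds than this note shows. Statements on the series, on what has been measured and on what is new or still open speak of the compounds shown alone.

Compound 1 `C/C(=C\CC/C(C)=C/CC[C@@H]1[C@@]2(C)CCC(=O)C(C)(C)[C@H]2CC[C@@]1(C)O)CC/C=C(\C)C(=O)OCc1cn(-c2ccccc2Br)nn1` carries a 1-(2-bromophenyl)-1H-1,2,3-triazol-4-yl group on the shared core. In a functional assay on DU-145 cells (Homo sapiens) for antiproliferative activity, read by MTT assay, with a stated time of 48 h (on this read-out higher numbers stand for weaker inhibition and lower numbers for stronger inhibition), compound 1 gives > 150000 nM, which is a limit of the assay rather than a number. Compound 2 `C/C(=C\CC/C(C)=C/CC[C@@H]1[C@@]2(C)CCC(=O)C(C)(C)[C@H]2CC[C@@]1(C)O)CC/C=C(\C)C(=O)OCc1cn(-c2cccc(F)c2)nn1` gives > 150000 nM in this assay, again a limit. Compound 3 `C/C(=C\CC/C(C)=C/CC[C@@H]1[C@@]2(C)CCC(=O)C(C)(C)[C@H]2CC[C@@]1(C)O)CC/C=C(\C)C(=O)OCc1cn(-c2ccccc2Cl)nn1` gives > 150000 nM in this assay, also a limit. Compound 1 therefore stands where every measured compound stands, at the limit of the assay (the limit of > 150000 nM in this assay, at which 3 of the 3 values shown sit). The sizes of the steps a step that the two limits leave unreadable from compound 1 to compound 2, a step that the two limits leave unreadable from compound 1 to compound 3 and a step that the two limits leave unreadable from compound 2 to compound 3 cannot be read, since each joins two limits.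

Compound 4 `C/C(=C\CC/C(C)=C/CC[C@@H]1[C@@]2(C)CCC(=O)C(C)(C)[C@H]2CC[C@@]1(C)O)CC/C=C(\C)C(=O)OCc1cn(-c2cccc(O)c2)nn1` has not been measured. It differs from compound 1 by 3-hydroxyphenyl in place of 2-bromophenyl on an aromatic nitrogen. Going by the values given here, the measured step that bears most closely on it is a step that the two limits leave unreadable from compound 1 to compound 2, which also exchanges the aryl group on the aromatic nitrogen, yet its size is unreadable, and no measured step introduces a hydroxyl. Because all three measured values sit at the limit (the limit of > 150000 nM in this assay, at which 3 of the 3 values shown sit), no direction can be read from them. He expects compound 4 to remain at or close to that limit, so that the estimated step that the limit leaves unreadable from compound 1 to compound 4 amounts to nothing beyond the scatter. His estimate for compound 4 in this assay is 200000 nM, within a range of 60000 nM to 600000 nM.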

Compound 4, half-maximal inhibitory concentration: 28400 nM
Compound 4: middle estimate off by 7.0-fold (0.85 log units), on the high side, outside the stated range (below it).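

The aryl group on the aromatic nitrogen is not silent in this assay: 3-hydroxyphenyl gives an at least 5.2-fold lower number from compound 1 to compound 4 (0.72 log units; beyond the scatter) and an at least 5.2-fold lower number from compound 3 to compound 4 (0.72 log units; beyond the scatter), so a change at this position can bring the read-out off the limit shared by the halogen-bearing compounds. The tightest comparison is hydroxy in place of fluoro on an aromatic carbon, with an at least 5.2-fold lower number from compound 2 to compound 4 (0.72 log units; beyond the scatter), which shows that exchanging this one substituent on the phenyl ring is enough to produce a readable value. Each of these steps has a limit at one end, so its full size stays unknown, and compound 4 alone has moved off that limit: the limit of > 150000 nM in this assay, at which 3 of the 4 values shown sit.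

The compounds shown leave open whether a methoxy group, an amine or a carboxylic acid in place of the hydroxy group would also give a readable value. They also leave open how much the place of the hydroxy group on the phenyl ring matters, since compound 1 and compound 3 differ from compound 4 in both the substituent and where it sits.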